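Methyl Added to a Second Aromatic Ring: an Expected Step

The source may report more compounds than this note shows. Statements on the series, on what has been measured and on what is new or still open speak of the compounds shown alone.

Measured so far:
- Compound 1 `O=C(Nc1cnn(-c2ccccc2)c1)c1cccc(NS(=O)(=O)c2ccccc2)c1` gives 26800 nM in a functional assay on A549 cells (Homo sapiens) for inhibition, read by MTT assay, with a stated time of 48 h; a lower number here means a stronger inhibitor, a higher number a weaker inhibitor.
- Compound 2 `Cc1ccc(-n2cc(NC(=O)c3cccc(NS(=O)(=O)c4ccccc4)c3)cn2)cc1` gives 18900 nM in this assay.
- Compound 3 `O=C(Nc1cnn(-c2ccccc2)c1)c1cccc(NS(=O)(=O)c2ccc(Cl)cc2)c1` gives 19300 nM in this assay.

Compound 2 differs from compound 1 by methyl in place of hydrogen on an aromatic carbon. That change made a 1.4-fold lower number from compound 1 to compound 2 (0.15 log units; within the scatter), a step too small to count as a real difference between the two compounds. Compound 3 differs from compound 1 in its core by chloro in place of hydrogen on an aromatic carbon, and this gave a 1.4-fold lower number from compound 1 to compound 3 (0.14 log units; within the scatter), again within the usual scatter. The unmeasured compound 4 `Cc1ccc(-n2cc(NC(=O)c3cccc(NS(=O)(=O)c4ccc(Cl)cc4)c3)cn2)cc1` differs from compound 3 by methyl in place of hydrogen on an aromatic carbon; the surroundings of the place are the same as in the step from compound 1 to compound 2, so this is the same change made on the core of compound 3.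

For compound 4, a step of about a 1.4-fold lower number from compound 3 to compound 4 (0.14 log units; within the scatter) in this assay is expected, because the same change earlier gave a 1.4-fold lower number from compound 1 to compound 2 (0.15 log units; within the scatter). Compound 4 is therefore estimated at 14000 nM in this assay, with a likely range from 7000 nM to 28000 nM.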

Compound 4, half-maximal inhibitory concentration: 15600 nM
Compound 4: the middle estimate sits 1.1-fold (0.05 log units) below what was measured; low and high end bracket the measured number.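

In this assay the methyl step on the core of compound 3 (a 1.2-fold lower number from compound 3 to compound 4 (0.09 log units; within the scatter)) agrees with the same step on the core of compound 1: (the same change on two cores in this assay, a 1.4-fold lower number (0.15 log units; within the scatter) from compound 1 to compound 2 and a 1.2-fold lower number (0.09 log units; within the scatter) from compound 3 to compound 4, 1.1-fold (0.06 log units) apart, within the scatter of two such steps). The chloro step on the core of compound 2 (a 1.2-fold lower number from compound 2 to compound 4 (0.08 log units; within the scatter)) also agrees with its earlier counterpart: (the same change on two cores in this assay, a 1.4-fold lower number (0.14 log units; within the scatter) from compound 1 to compound 3 and a 1.2-fold lower number (0.08 log units; within the scatter) from compound 2 to compound 4, 1.1-fold (0.06 log units) apart, within the scatter of two such steps). Among these compounds, neither change gave a step beyond the scatter on either core, so these four compounds show only that both changes stayed within the scatter on both cores, not that a real effect of either group carries from one core to another.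

The compounds shown leave open whether another group in place of the methyl or chloro, such as an amine, a carboxylic acid or a longer chain, would give a step beyond the scatter. They also leave open whether a step of that size would carry from one core to the other.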